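Dropping the methyl from compound 1

This account rests on a few compounds, and the source may have more. Where it says the series, first, only, none or still open, it means among the compounds named here.

For the measured compounds named here, in a functional assay on cells (Panel ovarian (Carcinoma cell lines), Homo sapiens) for inhibition (on this read-out higher numbers stand for weaker inhibition of growth and lower numbers for stronger inhibition of growth), compound 1 (`Cc1ccnc2nc(-c3cccc(Cl)c3)cc(O)c12`) gives 27500 nM and holds the higher of the two numbers measured so far. In this assay compound 2 (`Cc1cc(C)c2c(O)cc(-c3cccc(F)c3)nc2n1`) gives 5500 nM and the gap between the two values lies beyond the usual scatter. Of this pair, compound 1 is the weaker inhibitor of growth.

Going by the values given here, compound 3 (`Oc1cc(-c2cccc(Cl)c2)nc2ncccc12`) has no measurement yet. Its change from compound 1 (hydrogen in place of methyl on an aromatic carbon) is hydrogen in place of methyl on an aromatic carbon, opposite the ring nitrogen. Among the compounds with values here, no measured pair shows this change on its own, so the data give neither a size nor a direction for it. The expectation therefore starts from compound 1 at 27500 nM and assumes no shift beyond the scatter in this assay in either direction. The estimated step of a 1.1-fold lower number from compound 1 to compound 3 (0.02 log units; within the scatter) is expected to stay within that scatter. For compound 3 the estimated value is 26000 nM with an expected range from 10000 nM to 65000 nM in this wide first guess.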

Compound 3, concentration for total growth inhibition: 31600 nM
Compound 3: the middle estimate sits 1.2-fold (0.08 log units) below what was measured; low and high end bracket the measured number.
By their numbers in this assay, from the lowest: compound 2; then compounds 1 and 3 (each within the scatter of the next).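

In this assay, hydrogen in place of methyl on an aromatic carbon, opposite the ring nitrogen, gives a 1.1-fold higher number from compound 1 to compound 3 (0.06 log units; within the scatter). For the compounds shown here, this is the first direct reading for this change: in this pair, with the rest of the core of compound 1 kept, removing the methyl leaves growth inhibition unchanged within the scatter, so the methyl at this place is not required to hold the level seen for compound 1. No supporting data bear on why the step is this small.

From the compounds shown here alone, the reading rests on a single pair with a methyl and a hydrogen at this place, so it remains open whether an ethyl chain, a methoxy group, an amine or a carboxylic acid there would leave the number just as flat. Going by these compounds, compound 2 differs from compound 1 in more than one place, so it remains open whether the same change would also be silent on the core of compound 2, which carries fluorine on its phenyl ring and a second methyl.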